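Pyridin-2-yl for Phenyl on a Shared Triazole Scaffold

The source may report more compounds than this note shows. Statements on the series, on what has been measured and on what is new or still open speak of the compounds shown alone.

Compound 1 `Cc1ccc(-c2cn(C[C@H]3c4c(ccc(OS(=O)(=O)c5ccc(C)cc5)c4C)[C@@H]4CC[C@@]5(C)C[C@]43CC5=O)nn2)cc1`: > 20000 nM
Compound 2 `Cc1ccc(S(=O)(=O)Oc2ccc3c(c2C)[C@H](Cn2cc(-c4ccccc4)nn2)[C@@]24CC(=O)[C@@](C)(CC[C@@H]32)C4)cc1`: > 20000 nM

In a functional assay on A549 cells (Homo sapiens) for cytotoxicity, read by MTT assay, with a stated time of 4 days (on this read-out lower numbers stand for stronger inhibition and higher numbers for weaker inhibition), compound 1 reaches only a limit of the assay, > 20000 nM. Compound 2 likewise stands at a limit, > 20000 nM, so no number is known for it. Within the data shown here, the single measured step, a step that the two limits leave unreadable from compound 1 to compound 2, cannot be read because both values sit at the limit of > 20000 nM in this assay, at which 2 of the 2 values shown sit. Compound 3 `Cc1ccc(S(=O)(=O)Oc2ccc3c(c2C)[C@H](Cn2cc(-c4ccccn4)nn2)[C@@]24CC(=O)[C@@](C)(CC[C@@H]32)C4)cc1` carries pyridin-2-yl in place of phenyl on an aromatic carbon. Among the measured compounds shown here, no measured step bears on this change, so the step that the limit leaves unreadable from compound 2 to compound 3 is expected to stay within the scatter, most likely as another limit. Compound 3 is therefore estimated at 30000 nM, between 8000 nM and 100000 nM.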

Compound 3, half-maximal inhibitory concentration: > 20000 nM
Compound 3: no number, only a limit; the forecaster's own chance of this, stated with the estimate: 80%; the middle value is on the limit's open side.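

Compound 3 also stops at a limit rather than a number, so its steps from compound 1 and compound 2 cannot be read: the limit of > 20000 nM in this assay, at which 3 of the 3 values shown sit. On these data alone, whether 4-methylphenyl, phenyl and pyridin-2-yl differ in strength at all stays open.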